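A few compounds are considered here, and "the series" means these few. Any claim that something is new, unique, unknown or untested is made for them only; others in the source may bear on it.

Measured in an ADME assay on CHO-K1 cells (Cricetulus griseus) for cytotoxicity, read by MTT assay, with a stated time of 24 h; a lower number here means that less compound is tolerated, a higher number that more compound is tolerated:
- Compound 1 `Oc1cccc(NC(=S)Nc2ccc3[nH]ccc3c2)c1`: 977000 nM
- Compound 2 `Oc1ccc(NC(=S)Nc2ccc3[nH]ccc3c2)cc1`: 848000 nM
- Compound 3 `S=C(Nc1ccc(Oc2ccccc2)cc1)Nc1ccc2[nH]ccc2c1`: 36000 nM

Compound 3 holds the lowest of these three numbers, beyond the scatter from both others. Compound 4 `CCOC(=O)c1ccc(NC(=S)Nc2ccc3[nH]ccc3c2)cc1` has ethoxycarbonyl in place of phenoxy on an aromatic carbon. For the measured compounds named here, one measured step bears on this, and it was large: a 24-fold lower number from compound 2 to compound 3 (1.37 log units; beyond the scatter). Going by the values given here, it introduced the phenoxy that now leaves, so a partial return toward compound 2 at 848000 nM is expected, though no measured step covers ethoxycarbonyl. A clear rise beyond the scatter is therefore expected, estimated as a 4.2-fold higher number from compound 3 to compound 4 (0.62 log units; beyond the scatter). For compound 4 the estimated value is 150000 nM, with an expected range of 50000 nM to 500000 nM.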

Compound 4, concentration lethal to 50% of the cells: 123000 nM
Compound 4: the middle estimate sits 1.2-fold (0.09 log units) above what was measured, and the stated range covers the measured number.
By their numbers in this assay, from the lowest: compound 3; then compound 4; then compounds 2 and 1 (each within the scatter of the next).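

In this assay, ethoxycarbonyl in place of phenoxy gives only a partial return, with a 3.4-fold higher number from compound 3 to compound 4 (0.53 log units; beyond the scatter), while a 6.9-fold lower number from compound 2 to compound 4 (0.84 log units; beyond the scatter) shows that it stays well short of the hydroxy compound. The lower number at this position therefore does not require an added aromatic ring, since ethoxycarbonyl has no ring and still lies beyond the scatter from hydroxy. No measured finding here explains either step. From the compounds shown here alone, whether an amine, a carboxylic acid or a longer alkyl chain at this carbon would sit nearer hydroxy or phenoxy remains open.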